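The source may report more compounds than this note shows. Statements on the series, on what has been measured and on what is new or still open speak of the compounds shown alone.

Measured in a physicochemical assay for lipophilicity, using the shake flask method, in phosphate buffer, measured as octanol-water partition, with a stated time of 24 h, at pH 7.4, tested at 100 uM; on this read-out higher numbers stand for higher lipophilicity and lower numbers for lower lipophilicity
- compound 1 `Cc1cccc(C)c1-c1cccc(COc2ccc(S(=O)(=O)CC(=O)O)cc2)c1` gives 2.49
- compound 2 `Cc1ccccc1-c1cccc(COc2ccc(S(=O)(=O)CC(=O)O)cc2)c1` gives 2.35
- compound 3 `O=C(O)CS(=O)(=O)c1ccc(OCc2cccc(-c3ccccc3Cl)c2)cc1` gives 2.47

Compound 3 sits close to both of the others. The step of a number 0.02 log units lower from compound 1 to compound 3 (within the scatter) and the step of a number 0.12 log units higher from compound 2 to compound 3 (within the scatter) are both small, so this assay does not separate these three compounds.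

Compound 4 `O=C(O)CS(=O)(=O)c1ccc(OCc2cccc(-c3ccccc3C(F)(F)F)c2)cc1` differs from compound 3 in one group: trifluoromethyl in place of chloro on an aromatic carbon, ortho to a large group (trifluoromethyl in place of chloro on an aromatic carbon). Within the data shown here, no measured compound carries trifluoromethyl, so no measured step shows this exchange directly. The nearest guide is chloro in place of methyl, the step of a number 0.12 log units higher from compound 2 to compound 3 (within the scatter) in this series. Hydrogen in place of methyl, the step of a number 0.14 log units lower from compound 1 to compound 2 (within the scatter) here, is also small. With both of these inside the scatter, only a small change is expected, perhaps slightly upward. The expected step is a number 0.08 log units higher from compound 3 to compound 4 (within the scatter) and no more than the scatter allows. The estimate for compound 4 is 2.55 with an expected range from 2.3 to 2.85 for most repeat measurements.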

Compound 4, distribution coefficient: 2.95
For compound 4 the middle estimate is 0.40 log units below the measured one, outside the stated range (above it).
By their numbers in this assay, from the lowest: compounds 2, 3 and 1 (each within the scatter of the next); then compound 4.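

In this assay the group on this aromatic carbon turns out to matter: the earlier exchanges all stayed within the scatter, but trifluoromethyl in place of chloro gives a number 0.48 log units higher from compound 3 to compound 4 (beyond the scatter) and so produces the first clear separation in the series. The same group in place of methyl gives a number 0.60 log units higher from compound 2 to compound 4 (beyond the scatter) as a second clear step. Against the 2,6-dimethylphenyl compound, the 2-(trifluoromethyl)phenyl group gives a number 0.46 log units higher from compound 1 to compound 4 (beyond the scatter) as a third, so compound 4 stands clearly highest of the four compounds shown.

Going by these compounds, it remains open whether other groups at this place, such as a nitrile, a methoxy group or a longer chain like ethyl, would shift the number as far as trifluoromethyl does. No supporting information is available on what lies behind these steps.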